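A few compounds are considered here, and "the series" means these few. Any claim that something is new, unique, unknown or untested is made for them only; others in the source may bear on it.

Measured compounds:
- compound 1, `CCOC(=O)CSc1nc(Cl)cc(Nc2cccc(C)c2C)n1`, activity 76.9%
- compound 2, `CCOC(=O)C(C)Sc1nc(Cl)cc(Nc2cccc(C)c2C)n1`, activity "not active" (no number reported), with no number given

In an assay for inhibition of Polyunsaturated fatty acid 5-lipoxygenase (Homo sapiens), tested at 1 uM (a higher number here means a weaker effect of the compound at the concentration tested, a lower number a stronger effect), compound 1 gives 76.9%. Compound 2 stands apart from that: no single number is available for it, only the report that it showed no activity, so it cannot be placed against compound 1 on a scale. Compound 3, `Cc1cccc(Nc2cc(Cl)nc(SC(C)C(=O)O)n2)c1C`, has not been measured yet. It differs from compound 2 in one place: hydrogen in place of ethyl on an oxygen next to a carbonyl group. For the measured compounds named here, no step between measured compounds is available to set the size of such a change, so the expectation rests on the weak result of compound 1 and the inactive report of compound 2. In this assay compound 3 is expected to remain at the weak end, with a small step at most, in either direction, beyond the scatter. The estimate for compound 3 is 90%, in the range 70% to 110%.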

Compound 3, a percentage reported as activity, at one concentration (the size of the read-out at that concentration, not a potency): "not active" (no number reported)
Compound 3: no number reported; the estimate stays without a comparison.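

Compound 2 and compound 3 are both reported only as not active, with no number, so no step can be read between them. The compounds shown leave open whether going from ethoxycarbonyl to carboxy changes the activity at all. No available evidence bears on this result.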